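Nitro for iodo on a chalcone boronic acid

The source may report more compounds than this note shows. Statements on the series, on what has been measured and on what is new or still open speak of the compounds shown alone.

Compound 1, `O=C(/C=C/c1ccc2c(c1)B(O)OC2)c1ccco1`, gives 7400 nM in a toxicity assay on MCF-10A cells (Homo sapiens) for cytotoxicity, read by MTT assay, with a stated time of 48 h; a lower number here means a stronger inhibitor, a higher number a weaker inhibitor.
Compound 2, `Cn1cccc1C(=O)/C=C/c1ccc2c(c1)B(O)OC2`, sits at a limit of this assay, > 100000 nM.
Compound 3, `O=C(/C=C/c1ccc2c(c1)B(O)OC2)c1ccc(I)cc1`, also sits at a limit of this assay, > 100000 nM.

Compound 3 therefore stands at the weak end of what is shown, with only a limit and no number, and the limit of > 100000 nM in this assay, at which 2 of the 3 values shown sit, marks that two of the three values rest there. Compound 4, `O=C(/C=C/c1ccc2c(c1)B(O)OC2)c1ccc([N+](=O)[O-])cc1`, differs from compound 3 by nitro in place of iodo on an aromatic carbon. Among the measured compounds shown here, no measured step exchanges one group for another on the phenyl ring; the steps that touch this part of the molecule are an at least 13-fold higher number from compound 1 to compound 3 (1.13 log units; beyond the scatter) and an at least 13-fold higher number from compound 1 to compound 2 (1.13 log units; beyond the scatter), both large, while a step that the two limits leave unreadable from compound 2 to compound 3 cannot be read. Those steps show that leaving furan-2-yl for either of the other groups lowers potency strongly, but they say nothing about how nitro compares with iodo. Compound 4 is thus expected to stay near the limit, and its step of a number no higher from compound 3 to compound 4 (the limit leaves the size open) is expected to be small. The estimate for compound 4 is 100000 nM, with a range from 30000 nM to 300000 nM.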

Compound 4, half-maximal inhibitory concentration: 17500 nM
Compound 4: middle estimate off by 5.7-fold (0.76 log units), on the high side; the measured number lies below the stated range.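

In this assay, nitro in place of iodo on an aromatic carbon gives an at least 5.7-fold lower number from compound 3 to compound 4 (0.75 log units; beyond the scatter). The earlier steps shown here showed only what happens when the whole group on the carbonyl carbon is exchanged, whereas this one shows that a single substituent on the six-membered aromatic ring, with the rest of the molecule unchanged, is enough to move the number off the limit. Compound 3 rests on a limit, so the full size of this step stays unknown: the limit of > 100000 nM in this assay, at which 2 of the 4 values shown sit.

From the compounds shown here alone, a single pair gives no trend, so it remains open how the number follows the group at this place. An amine or a carboxylic acid on the same aromatic carbon would show whether other groups also move the number off the limit.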